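This account rests on a few compounds, and the source may have more. Where it says the series, first, only, none or still open, it means among the compounds named here.

Compound 1 `COc1cc(-c2nn(-c3cccc(NC(=O)c4cccc(C(F)(F)F)c4)c3)cc2-c2ccncc2)ccc1Cl`: in a functional assay on PC-3 cells (Homo sapiens) for inhibition, read by sulforhodamine B assay, with a stated time of 48 h (a lower number here means a stronger inhibitor of growth, a higher number a weaker inhibitor of growth), compound 1 gives only a limit, > 50000 nM.
Compound 2 `COc1cc(-c2nn(-c3cccc(NC(=O)c4ccc(Cl)c(C(F)(F)F)c4)c3)cc2-c2ccncc2)ccc1Cl`: in this assay compound 2 also gives only a limit, > 32500 nM.

The step that the two limits leave unreadable from compound 1 to compound 2 is therefore unreadable, since one value sits at the limit of > 32500 nM in this assay, at which 1 of the 2 values shown sits, and the other at the limit of > 50000 nM in this assay, at which 1 of the 2 values shown sits. Compound 2 thus stands at a limit and not at a number. Compound 3 `COc1cc(-c2nn(-c3cccc(NC(=O)Nc4ccc(Cl)c(C(F)(F)F)c4)c3)cc2-c2ccncc2)ccc1Cl` differs from compound 2 by (4-chloro-3-(trifluoromethyl)phenyl)amino in place of 4-chloro-3-(trifluoromethyl)phenyl on a carbonyl carbon. Among the compounds with values here, no measured step bears on this change, and the only measured step gives no size. Compound 3 is expected to give about 40000 nM, within 10000 nM to 100000 nM. The step is estimated as a step that the limit leaves unreadable from compound 2 to compound 3, most likely ending again at a limit.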

Compound 3, concentration for total growth inhibition: 2450 nM
For compound 3 the middle estimate is 16-fold (1.21 log units) above the measured one; measured number below the stated range.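

In this assay, within the data shown here, the change on the carbonyl carbon gives the first step that can be read, an at least 13-fold lower number from compound 2 to compound 3 (1.12 log units; beyond the scatter), and compound 3 is the first compound here to give a number instead of a limit. Measured from compound 1, the change gives an at least 20-fold lower number from compound 1 to compound 3 (1.30 log units; beyond the scatter), which is only a bound, because compound 1 gives a limit: the limit of > 50000 nM in this assay, at which 1 of the 3 values shown sits. The step from compound 2 is likewise only a bound, because compound 2 also gives a limit: the limit of > 32500 nM in this assay, at which 1 of the 3 values shown sits.

As far as these compounds go, it remains open whether a methylamino or a methylene group in place of the new amino link on the carbonyl carbon would read as compound 3 does. From the compounds shown here alone, the step from compound 1 to compound 2 cannot be read, so what the chloro contributes also stays open.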